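Trimming the Branched Side Chain: Compound 2 to Compound 3

This account rests on a few compounds, and the source may have more. Where it says the series, first, only, none or still open, it means among the compounds named here.

Measured compounds:
- compound 1, `CC(=O)c1ccc(NC(=O)C(CC(C)C)N(C(=O)c2ccccc2)S(=O)(=O)c2ccccc2)cc1`, gives 46.9%
- compound 2, `CCC(C)C(C(=O)Nc1ccc(C(C)=O)cc1)N(C(=O)c1ccccc1)S(=O)(=O)c1ccccc1`, gives 15.5%

Among the compounds with values here, in a functional assay for inhibition, read by spectrophotometry, with a stated time of 20 min, tested at 4 mg/mL (on this read-out lower numbers stand for a weaker effect and higher numbers for a stronger effect at the one concentration tested), compound 2 stands lowest of the two numbers measured so far. Within the data shown here, its nearest neighbour is compound 1, and the only step among the measured compounds is a number 31.4 percentage points lower from compound 1 to compound 2 (beyond the scatter), a large fall.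

Compound 3 is `CC(=O)c1ccc(NC(=O)C(C(C)C)N(C(=O)c2ccccc2)S(=O)(=O)c2ccccc2)cc1`. It is built from compound 2 by a single change: hydrogen in place of methyl on a saturated chain carbon, three bonds along the chain from an amide-type nitrogen and a carbonyl carbon. After this change the side chain of compound 3 is the isopropyl group, which is branched at the same chain carbon as the sec-butyl of compound 2.

Among the measured compounds shown here, the one step that bears on this change is the swap of isobutyl for sec-butyl, which lowered the read-out sharply. That step shows how strongly this assay reacts to the shape of the side chain, but it does not show what removing a methyl from the sec-butyl group does. Because compound 2 gives 15.5% and compound 3 keeps the same branching point, the expected step is a number 6.5 percentage points higher from compound 2 to compound 3 (within the scatter), which is within the scatter. Compound 3 is therefore estimated at 22%, with a range from 5% to 48%.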

Compound 3, a percentage reported as inhibition, at one concentration (the size of the read-out at that concentration, not a potency): 52.2%
Beside the measured number, compound 3's estimate is 30.2 percentage points below it; measured number outside the range, above it.
By their numbers in this assay, from the lowest: compound 2; then compounds 1 and 3 (each within the scatter of the next).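

Removing a single methyl, which turns sec-butyl into isopropyl without moving the branch point, gives a number 36.7 percentage points higher from compound 2 to compound 3 (beyond the scatter) in this assay, so branching at that chain carbon is not enough on its own to bring the read-out down. Isopropyl in place of isobutyl gives a number 5.3 percentage points higher from compound 1 to compound 3 (within the scatter), which means this assay does not separate those two side chains, and among the three compounds only compound 2, with its sec-butyl group, stands apart from the others. Nothing on hand explains why one extra methyl at this place counts for so much.

The compounds shown cover only these three branched alkyl side chains, so it remains open how an unbranched chain such as n-butyl, a ring such as cyclohexyl, or a chain carrying an amine or a carboxylic acid would fare at this position. Each number also comes from a single concentration, so it tells only of a stronger or weaker effect at that concentration.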